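Saturating the chain of compound 2: working notes

The compounds below may be only part of what the source reports. "The series", "measured", "known", "first", "only" and "open" are said of these compounds alone.

compound 1 `CCCCC1([C@H](O)/C=C/C2CCC(=O)[C@@H]2CCCCCC(=O)O)CCC1` gives 0.032 mg/kg
compound 2 `CCCCC1([C@H](O)/C=C/C2CCC(=O)[C@@H]2C/C=C\CCCC(=O)O)CCC1` gives 0.0022 mg/kg
compound 3 `CCCCC1([C@H](O)/C=C/C2CCC(=O)[C@@H]2CCCCCCC(=O)O)CCC1` is not yet measured

In a functional assay on the whole organism (strain Hartley) for inhibition, with Cavia porcellus as the target, with stated times of 15 min and 2 min (on this read-out lower numbers stand for an effect already at smaller amounts and higher numbers for an effect only at larger amounts of compound), compound 2 holds the lower of the two numbers, with compound 1 as its nearest neighbour. The change under review leads to compound 3: 5-carboxypentyl in place of 5-carboxypent-1-en-1-yl on a saturated chain carbon bound to a saturated ring carbon. Within the data shown here, one measured step bears on it, a 15-fold lower number from compound 1 to compound 2 (1.16 log units; beyond the scatter), which is large. That step replaces 4-carboxybutyl with 5-carboxypent-1-en-1-yl, so it changes more than the double bond and gives only a loose guide. Taking a 15-fold lower number from compound 1 to compound 2 (1.16 log units; beyond the scatter) as an upper guide, a higher number is expected for compound 3 in this assay, though by a smaller step. The expected change is a 2.7-fold higher number from compound 2 to compound 3 (0.44 log units; beyond the scatter) and remains uncertain. For compound 3 the estimated value is 0.006 mg/kg, with an expected range from 0.0015 mg/kg to 0.02 mg/kg.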

Compound 3, dose for half-maximal effect: 0.0024 mg/kg
Beside the measured number, compound 3's estimate is 2.5-fold (0.40 log units) above it; the range from low to high includes it.
By their numbers in this assay, from the lowest: compounds 2 and 3 (each within the scatter of the next); then compound 1.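

In this assay the step of a 1.1-fold higher number from compound 2 to compound 3 (0.04 log units; within the scatter) shows that 5-carboxypentyl can stand in place of 5-carboxypent-1-en-1-yl on this saturated chain carbon bound to a saturated ring carbon with no difference beyond the scatter, so the double bond is not needed for the low number here. The step of a 13-fold lower number from compound 1 to compound 3 (1.12 log units; beyond the scatter) comes with carboxymethyl in place of carboxy, five bonds along the chain from a saturated ring carbon, which ties the large gap among these three compounds to chain length and not to the double bond. No measurement offered here bears on the reason for either result.

Still open, on these data alone, is how a longer chain than 5-carboxypentyl would read out. Also open, as far as these compounds go, is whether a tetrazole or a primary amide could replace the terminal carboxylic acid.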